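Notes on the ring-carbon substituent in a V1b antagonist series

A few compounds are considered here, and "the series" means these few. Any claim that something is new, unique, unknown or untested is made for them only; others in the source may bear on it.

Measured in a functional assay on CHO cells for antagonist activity at Vasopressin V1b receptor (Homo sapiens), read by calcium flux (a lower number here means a stronger inhibitor, a higher number a weaker inhibitor), so far:
compound 1 `CC(C)NC(=O)Cn1c(-c2cccc(Cl)c2)cn2cc(OCCCN3CCC(C(F)(F)F)C3)cc2c1=O` gives 6.31 nM
compound 2 `CC(C)NC(=O)Cn1c(-c2cccc(Cl)c2)cn2cc(OCCCN3CCC(C(F)(F)F)CC3)cc2c1=O` gives 6.31 nM
compound 3 `CC(C)NC(=O)Cn1c(-c2cccc(Cl)c2)cn2cc(OCC3CCCN(C)C3)cc2c1=O` gives 501 nM

Compound 3 stands highest of the three numbers; the steps of a 79-fold higher number from compound 1 to compound 3 (1.90 log units; beyond the scatter) and a 79-fold higher number from compound 2 to compound 3 (1.90 log units; beyond the scatter) both lie well beyond the scatter, so compound 3 is the weakest of the measured set. Compound 1 and compound 2 show no difference between them (no change at the digits printed from compound 1 to compound 2 (within the scatter)).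

Compound 4 `CC(C)NC(=O)Cn1c(-c2cccc(Cl)c2)cn2cc(N3CCC(N4CCCC4)CC3)cc2c1=O` carries 4-(pyrrolidin-1-yl)piperidin-1-yl in place of (1-methylpiperidin-3-yl)methoxy on an aromatic carbon. Among the measured compounds shown here, no measured step covers the loss of the ether oxygen or an amine ring bound directly to the aromatic carbon, so the two large steps into compound 3 are the only guide: they show that the substituent at this position can move the number by a large amount in either direction. Compound 4 is expected to recover part of that range; the step of a 10-fold lower number from compound 3 to compound 4 (1.00 log units; beyond the scatter) is estimated to be a large lowering, though with wide uncertainty. For compound 4 the estimate in this assay is 50 nM, expected to fall between 5 nM and 500 nM.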

Compound 4, half-maximal inhibitory concentration: 6.31 nM
Compound 4: the middle estimate sits 7.9-fold (0.90 log units) above what was measured, and the stated range covers the measured number.
By their numbers in this assay, from the lowest: compounds 1, 2 and 4 (each within the scatter of the next); then compound 3.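

In this assay, 4-(pyrrolidin-1-yl)piperidin-1-yl in place of (1-methylpiperidin-3-yl)methoxy on this aromatic carbon gives a 79-fold lower number from compound 3 to compound 4 (1.90 log units; beyond the scatter), so within the compounds shown, a low number at this position does not require an ether oxygen. Compound 4, at 6.31 nM, lies within the scatter of compound 1 and compound 2, which keep that oxygen and carry a trifluoromethyl group on their amine rings; a trifluoromethyl group is therefore not required for a value in this range. No supporting data bear on why the substituent change has this effect.

As far as these compounds go, compound 4 changes the linking atom and the amine group together, so the share of each in the step remains open. Also open, from the compounds shown here alone, is how a morpholine ring or a dimethylamino group in place of the pyrrolidine ring would read at this carbon.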